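Swapping hydroxyphenyl for bromophenyl: is tolerability unchanged?

The compounds below may be only part of what the source reports. "The series", "measured", "known", "first", "only" and "open" are said of these compounds alone.

Three amides sharing one core have been tested in a toxicity assay on THP-1 cells (Homo sapiens) for inhibition; a higher number here means that more compound is tolerated, a lower number that less compound is tolerated. Compound 3 `COc1ccc(-c2cnc(NC(=O)c3ccc(O)cc3)n2C)cc1` reaches only the limit of the assay, giving > 100000 nM. Compound 1 `COc1ccc(C(=O)Nc2ncc(-c3ccc(OC)cc3)n2C)cc1` likewise reports the limit, > 100000 nM. Compound 2 `COc1ccc(-c2cnc(NC(=O)c3ccccc3)n2C)cc1` sits at the same limit with > 100000 nM. The steps between these compounds are therefore not readable: a step that the two limits leave unreadable from compound 1 to compound 2, a step that the two limits leave unreadable from compound 1 to compound 3, and a step that the two limits leave unreadable from compound 2 to compound 3. What is known so far is summed up by the limit of > 100000 nM in this assay, at which 3 of the 3 values shown sit.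

Compound 4 `COc1ccc(-c2cnc(NC(=O)c3ccccc3Br)n2C)cc1` has not yet been measured. It differs from compound 3 in one place: 2-bromophenyl in place of 4-hydroxyphenyl on a carbonyl carbon. Among the measured compounds shown here, no measured step bears on this change, and the limit of > 100000 nM in this assay, at which 3 of the 3 values shown sit, hides the size of every step seen so far, so no direction can be read from them. Compound 4 is expected to sit at the limit as well, estimated at 100000 nM with a range from 40000 nM to 250000 nM. This estimate means a step of a number no higher from compound 3 to compound 4 (the limit leaves the size open), expected to be none beyond the scatter.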

Compound 4, half-maximal cytotoxic concentration: > 100000 nM
Compound 4: a limit, no number; the forecaster's own chance of this, stated with the estimate: 80%; the middle value sits exactly at the limit.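

No step between compound 4 and compound 1, compound 2 or compound 3 can be read, because each value is a limit and not a number: the limit of > 100000 nM in this assay, at which 4 of the 4 values shown sit.

The compounds shown leave open what concentration of any of them is actually tolerated in this assay, and whether any other group on the carbonyl carbon would lower it.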